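The source may hold more compounds than are shown below. What is called first, only, known or untested is meant among the compounds shown, and "the series" means these compounds.

Compound 1 `COc1cc2c(cc1OC)C(c1ccc(N)cc1)=NNC(=O)C2` gives 15 umol/kg in a functional assay on the whole organism with Mus musculus as the target; a lower number here means that less compound is needed, a higher number that more compound is needed for the effect. Compound 2 `COc1cc2c(cc1OC)C(c1ccc([N+](=O)[O-])cc1)=NNC(=O)C2` reaches only a limit of the assay, > 120 umol/kg, which is not a number (the limit of > 120 umol/kg in this assay, at which 1 of the 3 values shown sits). The step of an at least 8.0-fold higher number from compound 1 to compound 2 (0.90 log units; beyond the scatter) goes with the change (nitro in place of amino on an aromatic carbon). Compound 3 `COc1cc2c(cc1OC)C(c1ccc(N)cc1)=NN(C)C(=S)C2` gives 29.8 umol/kg in this assay; the difference between the core of compound 3 and the core of compound 1 is not broken down here. Compound 4 `COc1cc2c(cc1OC)C(c1ccc([N+](=O)[O-])cc1)=NN(C)C(=S)C2` is not yet measured in this assay. It differs from compound 3 by nitro in place of amino on an aromatic carbon, the same change as that between compound 1 and compound 2. Resting on compound 3 at 29.8 umol/kg and on the earlier step of an at least 8.0-fold higher number from compound 1 to compound 2 (0.90 log units; beyond the scatter), the expected step is an 8.4-fold higher number from compound 3 to compound 4 (0.92 log units; beyond the scatter). Compound 4 is therefore estimated at 250 umol/kg, most likely reported only as a limit.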

Compound 4, dose for half-maximal effect: 103 umol/kg
Beside the measured number, compound 4's estimate is 2.4-fold (0.39 log units) above it; measured number inside the range.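

In this assay, nitro in place of amino on an aromatic carbon also gives a higher number on the second core: a 3.5-fold higher number from compound 3 to compound 4 (0.54 log units; beyond the scatter). Compound 2 gives > 120 umol/kg, which is a limit of the assay and not a number. The change therefore goes in the same direction on both cores shown, but this does not establish that its size carries over from one core to the other: the same change on two cores in this assay, an at least 8.0-fold higher number (0.90 log units; beyond the scatter) from compound 1 to compound 2 and a 3.5-fold higher number (0.54 log units; beyond the scatter) from compound 3 to compound 4; the limit leaves it open whether they differ

As far as these compounds go, it remains open how other groups at this place on the aromatic ring, such as a dimethylamino group, an acetamide or a carboxylic acid, would compare with amino and nitro. Also open, from the compounds shown here alone, is how the change behaves on the core of compound 3 with a carbonyl in place of its thiocarbonyl.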